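The source may hold more compounds than are shown below. What is called first, only, known or untested is meant among the compounds shown, and "the series" means these compounds.

Measured so far:

- In a functional assay on CHO cells for antagonist activity at prostaglandin E2 receptor EP3 subtype (Homo sapiens), read by cAMP accumulation (on this read-out lower numbers stand for stronger inhibition and higher numbers for weaker inhibition), compound 1 (`CCC(CC)(c1nnc[nH]1)c1ccc(-c2ccc3cc(F)cc(F)c3c2)[nH]c1=O`) gives 350 nM.
- In this assay compound 2 (`CC(C)C(Nc1nnc[nH]1)c1ccc(-c2ccc3cccc(F)c3c2)[nH]c1=O`) gives 185 nM.

Compound 2 and compound 1 sit close together: the gap between their two numbers lies within the usual scatter of repeated measurements, so neither can be said to stand apart from the other on this read-out. Going by the values given here, both share the same core and differ at two places at once, so no single-change step between them is on record.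

Compound 3 (`CC(C)C(c1cnc(N)s1)c1ccc(-c2ccc3cccc(F)c3c2)[nH]c1=O`) has not been measured. It is built from compound 2 by one change: 2-amino-1,3-thiazol-5-yl in place of (4H-1,2,4-triazol-3-yl)amino on a saturated chain carbon bound to an aromatic carbon and a saturated chain carbon. The fluorinated bicyclic aryl group and the isopropyl-bearing chain are kept, and only the five-membered heteroaromatic unit attached to that chain carbon is exchanged.

Among the compounds with values here, no measured pair shows what this kind of exchange does, so the expectation rests on the change itself and on the narrow spread of the two known values. The step from compound 2 to compound 3 is expected to be small, about a 1.6-fold higher number from compound 2 to compound 3 (0.21 log units; within the scatter), with a slight lean toward a weaker result rather than a stronger one. Compound 3 is therefore estimated at 300 nM in this assay, within a range from 80 nM to 1200 nM.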

Compound 3, half-maximal inhibitory concentration: 39 nM
The estimate for compound 3 lay 7.7-fold (0.89 log units) above the measured number; measured number below the stated range.
By their numbers in this assay, from the lowest: compound 3; then compounds 2 and 1 (each within the scatter of the next).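

In this assay, going by these compounds alone, the step to the 2-amino-1,3-thiazol-5-yl group gives a 4.7-fold lower number from compound 2 to compound 3 (0.68 log units; beyond the scatter), the first single-change step and one that stands beyond the scatter. It shows that the read-out responds to what sits on this saturated chain carbon, even though the group that leaves and the group that enters have the same count of heavy atoms, each hold one five-membered aromatic ring and carry no net charge; they differ in the ring's hetero atoms, in the sulfur atom that enters and in their hydrogen-bond donors. Nothing available here connects the step to any one of these differences.

The compounds shown leave open whether the amine on the thiazole ring matters, which a plain 1,3-thiazol-5-yl group would test, and whether the sulfur does, which a 2-amino-1,3-oxazol-5-yl group would test. They also leave open whether the same exchange would give a similar step on the chain and aryl group of compound 1, which differ from those of compound 3.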